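The source may report more compounds than this note shows. Statements on the series, on what has been measured and on what is new or still open speak of the compounds shown alone.

Measured compounds and their values:

Compound 1, `Cc1csc(N)c1C(=O)c1ccc(Cl)cc1`: 1%
Compound 2, `CC(C)(C)Cc1c(-c2c(F)cccc2F)sc(N)c1C(=O)c1ccc(Cl)cc1`: 1%
Compound 3, `CC(C)(C)Cc1c(-c2ccccc2)sc(N)c1C(=O)c1ccc(Cl)c(Cl)c1`: 6%

All three were tested in an assay on CHO cells for displacement of a labelled ligand from adenosine receptor A3 (Homo sapiens), read by scintillation counting, tested at 10 uM; a lower number here means less inhibition, a higher number more inhibition at the concentration tested (going by the name of the read-out). In this assay compound 2 gives 1%, the same number at the digits shown as compound 1, and these two share the low end of the three results. The nearest neighbour of compound 2 is compound 1, with no difference at the digits shown. The furthest is compound 3, whose number is a few points higher, yet still within the usual scatter of repeated measurements, so none of the three can be told apart on these numbers; all three show essentially no displacement of the labelled ligand at the concentration tested.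

The next compound, compound 4, `CC(C)(C)Cc1c(-c2cccs2)sc(N)c1C(=O)c1ccc(Cl)cc1`, keeps the shared core and the (4-chlorophenyl)carbonyl group of compound 2 and alters the aryl group beside the ring sulfur: thiophen-2-yl in place of 2,6-difluorophenyl on an aromatic carbon.

Among the compounds with values here, no measured pair differs in exactly one place, so there is no step to lean on. Given that compound 2 gives 1% and compound 3 gives 6%, a change of the aryl group here is expected to leave the result unchanged, and the step of a number 2 percentage points higher from compound 2 to compound 4 (within the scatter) is expected to be none beyond the scatter. For compound 4 the estimated value in this assay is 3%, with an expected range from 0% to 12%.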

Compound 4, a percentage reported as inhibition, at one concentration (the size of the read-out at that concentration, not a potency): 1%
Compound 4: middle estimate off by 2 percentage points, on the high side, within the range that was stated.
By their numbers in this assay, from the lowest: compounds 1, 2, 4 and 3 (each within the scatter of the next).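

Within the data shown here, this is the first pair in the set that differs in one place only, so the aryl group on the aromatic carbon next to the ring sulfur can be judged on its own: in this assay, the step for thiophen-2-yl in place of 2,6-difluorophenyl is no change at the digits printed from compound 2 to compound 4 (within the scatter) and nothing more. Replacing a six-membered aromatic ring of carbon only with a five-membered aromatic ring holding one sulfur therefore leaves the read-out unmoved, but both compounds show essentially no displacement of the labelled ligand, so the pair cannot show whether this position would matter in a compound that does displace it. No measurement bearing on the cause of this flat result is available.

As far as these compounds go, whether any group at this position can raise the result remains open, for instance a phenyl ring carrying an amine or a carboxylic acid, or a longer alkyl chain in place of the ring. Also open, from the compounds shown here alone, is how the result would respond to a change at the neopentyl group or the amino group, with the thiophen-2-yl group kept in place.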